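Series notes: third methoxy on the pendant ring

The compounds below may be only part of what the source reports. "The series", "measured", "known", "first", "only" and "open" are said of these compounds alone.

Compound 2 `CCOc1cccc2cc(-c3ccc(OC)c(OC)c3)c(=O)oc12` stands with the highest number of the two measured in an assay on CHO cells for displacement of a labelled ligand from adenosine receptor A3 (Homo sapiens), read by radioligand binding (a lower number here means a stronger inhibitor, a higher number a weaker inhibitor), giving 13700 nM, while compound 1 `CCOc1cccc2cc(-c3ccc(OC)cc3)c(=O)oc12` gives 5320 nM. Compound 3 `CCOc1cccc2cc(-c3cc(OC)c(OC)c(OC)c3)c(=O)oc12` differs from compound 2 by methoxy in place of hydrogen on an aromatic carbon, at a carbon ortho to a methoxy group and meta to a methoxy group. Among the compounds with values here, the one bearing step is a 2.6-fold higher number from compound 1 to compound 2 (0.41 log units; beyond the scatter), the same kind of change one carbon removed. A further modest rise in this assay is therefore expected, a 1.8-fold higher number from compound 2 to compound 3 (0.26 log units; within the scatter). Compound 3 is estimated at 25000 nM, likely between 10000 nM and 60000 nM.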

Compound 3, inhibition constant: 9050 nM
Compound 3: the middle estimate sits 2.8-fold (0.44 log units) above what was measured, and the stated range ends above it.
By their numbers in this assay, from the lowest: compounds 1, 3 and 2 (each within the scatter of the next, the first and the last beyond it).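

Methoxy in place of hydrogen at this carbon, ortho to a methoxy group and meta to a methoxy group, gives a 1.5-fold lower number from compound 2 to compound 3 (0.18 log units; within the scatter) in this assay and leaves the number within the scatter of compound 2. The same change elsewhere on the ring gave a 2.6-fold higher number from compound 1 to compound 2 (0.41 log units; beyond the scatter) and that rise is not repeated at this carbon. No evidence at hand bears on the difference between the two carbons.

Open, on these data alone, is whether hydroxy, an amine or a carboxylic acid at this carbon would move the number. As far as these compounds go, a longer chain such as propoxy there is equally open.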